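A few compounds are considered here, and "the series" means these few. Any claim that something is new, unique, unknown or untested is made for them only; others in the source may bear on it.

Compound 2 `COc1ncc(-c2ccc3ncnc(N[C@H]4CCN(C(=O)C5CCOCC5)C4)c3c2)cc1C#N` gives 570 nM in a functional assay on Ramos cells (Homo sapiens) for antiproliferative activity, read by MTT assay, with a stated time of 72 h (on this read-out higher numbers stand for weaker inhibition and lower numbers for stronger inhibition), and lies within the scatter of compound 1 `COc1ccc(-c2ccc3ncnc(N[C@H]4CCN(C(=O)C5CC5)C4)c3c2)cn1` at 520 nM on the two numbers available. Compound 3 `COc1ncc(-c2ccc3ncnc(N[C@H]4CCN(C(=O)C5CCOCC5)C4)c3c2)cc1[N+](=O)[O-]` differs from compound 2 by nitro in place of cyano on an aromatic carbon, ortho to a methoxy group nitro in place of cyano on an aromatic carbon and nothing else. For the measured compounds named here, no measured pair tests this position, so the expectation rests on compound 2 alone. The expected step is a 1.1-fold higher number from compound 2 to compound 3 (0.02 log units; within the scatter) and none beyond the scatter is foreseen in this assay for this change. Compound 3 is estimated at 600 nM with an expected range of 200 nM to 1800 nM as the working figure.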

Compound 3, half-maximal inhibitory concentration: 780 nM
Compound 3: middle estimate off by 1.3-fold (0.11 log units), on the low side; the measured number falls inside the stated range.
By their numbers in this assay, from the lowest: compounds 1, 2 and 3 (each within the scatter of the next).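

Nitro in place of cyano, ortho to a methoxy group, gives the first measured step at this position: in this assay it reads a 1.4-fold higher number from compound 2 to compound 3 (0.14 log units; within the scatter) and leaves the two groups indistinguishable on this read-out. This position therefore accepts either group here, with 3 heavy atoms entering for 2 leaving. No available measurement bears on this result.

On these data alone, whether an amine, a carboxylic acid or a bare hydrogen at this position would give a step beyond the scatter remains open. So does whether the same exchange reads alike with the amide of compound 1.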